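Ester Change Tested on the Most Stable Compound

The source may hold more compounds than are shown below. What is called first, only, known or untested is meant among the compounds shown, and "the series" means these compounds.

For the measured compounds named here, in an ADME assay on microsomes from liver (Homo sapiens) for metabolic stability, with a stated time of 30 min (a lower number here means that less of the compound is left, a higher number that more of the compound is left), compound 3 `CCCCc1nc(C)c(CC(=O)OC)c(=O)n1Cc1ccc(-c2ccccc2-c2noc(=O)[nH]2)cc1` gives 69.6%, the highest of the three numbers measured so far. Compound 1 `CCCCc1nc(C(C)C)c(CC(=O)OC)c(=O)n1Cc1ccc(-c2ccccc2-c2noc(=O)[nH]2)cc1` gives 10.5% and compound 2 `CCCCCOC(=O)Cc1c(C(C)C)nc(CCCC)n(Cc2ccc(-c3ccccc3-c3noc(=O)[nH]3)cc2)c1=O` gives 10.6%. Compound 4 `CCCCc1nc(C)c(CC(=O)OC2CCCCC2)c(=O)n1Cc1ccc(-c2ccccc2-c2noc(=O)[nH]2)cc1` differs from compound 3 by cyclohexyl in place of methyl on an oxygen next to a carbonyl group. One earlier step changed the same oxygen next to a carbonyl group: a number 0.1 percentage points higher from compound 1 to compound 2 (within the scatter). The large step of a number 59.1 percentage points higher from compound 1 to compound 3 (beyond the scatter) concerns a different place and is already built into compound 3. Because a number 0.1 percentage points higher from compound 1 to compound 2 (within the scatter) stayed within the scatter, the expected step of a number 4.6 percentage points lower from compound 3 to compound 4 (within the scatter) is none beyond the scatter. Compound 4 is therefore estimated at 65%, with a range from 45% to 82%.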

Compound 4, percent of the compound remaining: 3.9%
Compound 4: the middle estimate sits 61.1 percentage points above what was measured; the whole stated range lies above it.
By their numbers in this assay, from the lowest: compounds 4, 1 and 2 (each within the scatter of the next); then compound 3.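

Cyclohexyl in place of methyl on the oxygen next to a carbonyl group gives a number 65.7 percentage points lower from compound 3 to compound 4 (beyond the scatter) in this assay, so this oxygen is not a place where changes are always without effect. The earlier step at the same oxygen, a number 0.1 percentage points higher from compound 1 to compound 2 (within the scatter), started from compound 1 at 10.5%, where little was left already. That flat step therefore did not carry over to the methyl compound.

Nothing shown here gives a reason for the drop. Going by these compounds, whether an ethyl ester or a carboxylic acid at this place leaves more of the compound stays open.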